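Fluorines Replace a Methyl on the Sulfonyl Aryl Ring

The source may hold more compounds than are shown below. What is called first, only, known or untested is meant among the compounds shown, and "the series" means these compounds.

The study opens with two measured compounds. Compound 1 `O=C(NCc1ccc(S(=O)(=O)c2ccccc2)cc1)c1ccc2ccncc2c1` carries a plain phenyl on its sulfonyl sulfur, and in an ADME assay on microsomes from liver (Homo sapiens) for metabolic stability, read by LC-MS, with a stated time of 30 min, tested at 1 uM (a higher number here means that more of the compound is left, a lower number that less of the compound is left), compound 1 gives 46%. Compound 2 `Cc1cccc(S(=O)(=O)c2ccc(CNC(=O)c3cc4cnccc4[nH]3)cc2)c1` carries a 3-methylphenyl in that position and in this assay compound 2 gives 49%. Among the measured compounds shown here, compound 2 thus stands at the top of the two numbers known so far, yet its nearest neighbour, compound 1, lies within the scatter of it, so the two cannot be told apart on these data.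

The step followed here leads to compound 3 `O=C(NCc1ccc(S(=O)(=O)c2ccc(F)c(F)c2)cc1)c1cc2cnccc2[nH]1`, which is not yet measured in this assay. The change from compound 2 is 3,4-difluorophenyl in place of 3-methylphenyl on a sulfonyl sulfur. For the measured compounds named here, no step between measured compounds is recorded, so there is no direct precedent for what this swap does. Given how little the two known numbers differ, the account expects at most a small step upward in this assay, one that may well remain within the scatter, with an expected step of a number 7 percentage points higher from compound 2 to compound 3 (within the scatter). For compound 3 the estimate in this assay is 56%, with a range from 40% to 72%.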

Compound 3, percent of the compound remaining: 100%
For compound 3 the middle estimate is 44 percentage points below the measured one; the whole stated range lies below it.
By their numbers in this assay, from the lowest: compounds 1 and 2 (each within the scatter of the next); then compound 3.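

In this assay, among the compounds shown here, 3,4-difluorophenyl in place of 3-methylphenyl on a sulfonyl sulfur gives a number 51 percentage points higher from compound 2 to compound 3 (beyond the scatter), the first step at this position and one that shows the read-out can respond strongly to a change there. The change is small by count: 7 heavy atoms leave and 8 enter, the six-membered aromatic ring of carbon stays, and both groups have 0 hydrogen-bond donors, 0 hydrogen-bond acceptors and no net charge. Nothing measured here explains how the swap produces a step of this size.

The compounds shown leave open whether the step needs both fluorines or whether a single fluorine on the ring, as in 3-fluorophenyl or 4-fluorophenyl, would carry some or all of it, and whether a trifluoromethyl, a methoxy or an amine on that ring would hold the number of compound 3 at 100% in this assay. They also leave open whether the same swap would give a comparable step on the core of compound 1, which so far carries only a plain phenyl on its sulfonyl sulfur.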